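Swapping methoxy for chloro on a methylsulfonyl aniline core

The compounds below may be only part of what the source reports. "The series", "measured", "known", "first", "only" and "open" are said of these compounds alone.

Of the compounds shown here, three sharing one core have been measured in an assay for binding affinity to Alpha-1B adrenergic receptor (Homo sapiens), read by radioligand binding; on this read-out lower numbers stand for stronger inhibition and higher numbers for weaker inhibition. Compound 1 `COc1ccc(S(C)(=O)=O)c(NCC2=NCCN2)c1` gives 4570 nM, the highest of the three numbers. Compound 3 `CC(C)S(=O)(=O)c1ccccc1NCC1=NCCN1` gives 1000 nM in this assay, a lower number than compound 1 and beyond the scatter. Compound 2 `CS(=O)(=O)c1cc(F)ccc1NCC1=NCCN1` gives 513 nM in this assay, the lowest of the three numbers and the furthest from compound 1. No single change connects any two of these measured compounds, so what each pair shows is only the gap between its two values.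

Compound 4 `CS(=O)(=O)c1ccc(Cl)cc1NCC1=NCCN1` is not yet measured. It differs from compound 1 in one place: chloro in place of methoxy on an aromatic carbon. Among the measured compounds shown here, compound 2, the one measured compound that carries a halogen on the core, gives 513 nM in this assay, and on that basis compound 4 is expected to move to a lower number than compound 1, by a step of a 5.1-fold lower number from compound 1 to compound 4 (0.71 log units; beyond the scatter), beyond the scatter. Compound 4 is thus estimated at 900 nM in this assay, with a range from 250 nM to 3000 nM.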

Compound 4, inhibition constant: 2950 nM
Estimate against measurement, compound 4: 3.3-fold (0.52 log units) below; the measured number falls inside the stated range.
By their numbers in this assay, from the lowest: compounds 2 and 3 (each within the scatter of the next); then compounds 4 and 1 (each within the scatter of the next).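

In this assay, the step for chloro in place of methoxy on this aromatic carbon, para to a methylsulfonyl group, is a 1.5-fold lower number from compound 1 to compound 4 (0.19 log units; within the scatter). Among the compounds shown here, this is the first pair in the set that differs in one place, and it shows that on this read-out the two groups cannot be told apart at this position, although one heavy atom replaces two and the hydrogen-bond acceptor of the methoxy group is gone. Nothing available here accounts for this result.

From the compounds shown here alone, whether an amine or a carboxylic acid on the same aromatic carbon would give a number beyond the scatter of compound 1 stays open. So does whether chloro on another aromatic carbon of the shared core would behave as it does here.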